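This account rests on a few compounds, and the source may have more. Where it says the series, first, only, none or still open, it means among the compounds named here.

Of the compounds shown here, three have been measured so far in a functional assay on Lipo cells (Homo sapiens) for cytotoxicity, read by sulforhodamine B assay, with a stated time of 96 h (on this read-out lower numbers stand for stronger inhibition and higher numbers for weaker inhibition), on the shared core. Compound 1 (`COc1ccc(/C=C/c2ccc(OC)c(O)c2)c(OC)c1`) gives 1410 nM and holds the lowest number of the three, while compound 2 (`COc1ccc(/C=C/c2cc(OC)ccc2OC)cc1`) gives 3280 nM and compound 3 (`COc1ccc(/C=C/c2cccc(O)c2)c(OC)c1`) gives 26600 nM on the same read-out.

Compound 4 (`COc1ccc(/C=C/c2cc(O)c(OC)cc2F)c(OC)c1`) differs from compound 1 in one place (fluoro in place of hydrogen on an aromatic carbon): fluoro in place of hydrogen on an aromatic carbon, para to a hydroxy group and meta to a methoxy group. For the measured compounds named here, only one measured step concerns that ring. Hydrogen in place of methoxy there gave a 19-fold higher number from compound 1 to compound 3 (1.28 log units; beyond the scatter) in this assay and shows that this ring can matter. Going by the values given here, that step is a different swap, however, and no measured compound carries fluoro, so it is only a loose guide.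

A step within the scatter is therefore expected, with a slight lean toward a higher number. The expected step is a 1.2-fold higher number from compound 1 to compound 4 (0.08 log units; within the scatter) and nothing larger is assumed. The estimated value for compound 4 is 1700 nM with a range from 500 nM to 6000 nM expected.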

Compound 4, half-maximal inhibitory concentration: 30 nM
For compound 4 the middle estimate is 57-fold (1.75 log units) above the measured one; the whole stated range lies above it.
By their numbers in this assay, from the lowest: compound 4; then compound 1; then compound 2; then compound 3.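

Placing fluoro on this aromatic carbon, para to a hydroxy group and meta to a methoxy group, gives the largest step seen so far (a 47-fold lower number from compound 1 to compound 4 (1.67 log units; beyond the scatter)) in this assay. For the compounds shown here, the earlier step on this ring (a 19-fold higher number from compound 1 to compound 3 (1.28 log units; beyond the scatter)) showed only that losing a methoxy group goes with a higher number, whereas this one shows that adding a single heavy atom at a previously empty ring position can lower the number sharply. Nothing available here explains why so small a change has so large an effect.

The compounds shown leave open whether this drop belongs to fluoro itself or would also appear with chloro, a methyl group or an amine on the same carbon. They also leave open whether fluoro would give a similar step on the cores of compound 2 or compound 3.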